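The source may hold more compounds than are shown below. What is called first, only, known or untested is meant among the compounds shown, and "the series" means these compounds.

Compound 1, `CCC(=O)N(Cc1ccc(OC)c(O)c1)c1cc(OC)c(OC)c(OC)c1`, gives 61 nM in a functional assay on HCT-116 cells (Homo sapiens) for inhibition, read by MTT assay, with a stated time of 48 h; on this read-out lower numbers stand for stronger inhibition and higher numbers for weaker inhibition.
Compound 2, `C=C(C)C(=O)N(Cc1ccc(OC)c(O)c1)c1cc(OC)c(OC)c(OC)c1`, gives 200 nM.
Compound 3, `COc1ccc(CN(C(=O)C[Se]C#N)c2cc(OC)c(OC)c(OC)c2)cc1O`, gives 310 nM.

Compound 3 carries the highest of the three numbers in this assay. Its nearest neighbour is compound 2, separated by a 1.6-fold higher number from compound 2 to compound 3 (0.19 log units; within the scatter), a gap that stays within the scatter; its furthest is compound 1, separated by a 5.1-fold higher number from compound 1 to compound 3 (0.71 log units; beyond the scatter), a gap beyond the scatter.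

Compound 4, `COc1ccc(CN(C(=O)CBr)c2cc(OC)c(OC)c(OC)c2)cc1O`, is not yet measured. Relative to compound 3 the change is one bromine atom in place of a group of 3 heavy atoms (1 carbon, 1 nitrogen, 1 selenium; no ring), on a saturated chain carbon bound to a carbonyl carbon. For the measured compounds named here, the only measured step at this same place is a 5.1-fold higher number from compound 1 to compound 3 (0.71 log units; beyond the scatter), where a group of 3 heavy atoms entered in place of one carbon atom and the number rose beyond the scatter. Compound 4 moves back toward a single atom at that place, which argues for a number no higher than that of compound 3 and possibly lower. The step of a 3.3-fold higher number from compound 1 to compound 2 (0.52 log units; beyond the scatter) sits on the carbonyl carbon and bears only loosely. Going by the values given here, no measured compound carries bromo, so the size is uncertain. Compound 4 is therefore expected to show a step of a 1.7-fold lower number from compound 3 to compound 4 (0.24 log units; within the scatter), and its estimated value is 180 nM, within 60 nM to 600 nM.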

Compound 4, half-maximal inhibitory concentration: 68 nM
Compound 4: middle estimate off by 2.6-fold (0.42 log units), on the high side; the range from low to high includes it.
By their numbers in this assay, from the lowest: compounds 1 and 4 (each within the scatter of the next); then compounds 2 and 3 (each within the scatter of the next).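

In this assay, on the saturated chain carbon bound to a carbonyl carbon, bromo in place of the selenium-bearing group gives a 4.6-fold lower number from compound 3 to compound 4 (0.66 log units; beyond the scatter) and so shows that the number at this place can come back down after the rise seen with that group. Bromo in place of methyl at the same place gives a 1.1-fold higher number from compound 1 to compound 4 (0.05 log units; within the scatter), so within these compounds a single bromine atom on this carbon leaves the number level with that of the ethyl amide, and the place accepts at least one substituent other than methyl without a readable loss. Bromomethyl in place of 1-methylethenyl on a carbonyl carbon gives a 2.9-fold lower number from compound 2 to compound 4 (0.47 log units; beyond the scatter), which places compounds 1 and 4 together and apart from compound 2 on this read-out, so the acyl groups shown do not all behave alike.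

As far as these compounds go, whether chloro, an amine or a longer chain on this carbon would stay level with compounds 1 and 4 or move toward compounds 2 and 3 remains open. Nothing available here accounts for any of these steps.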